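The compounds below may be only part of what the source reports. "The series", "measured", "known", "first", "only" and "open" are said of these compounds alone.

Compound 1 `CCOC(=O)N1CCC(=NNC(=O)c2ccc([N+](=O)[O-])cc2)CC1` and compound 2 `CCOC(=O)N1CCC(=NNC(=O)c2ccc([N+](=O)[O-])cc2[N+](=O)[O-])CC1` share one core, while compound 3 `O=C(NN=C1CC(c2ccccc2)NC(c2ccccc2)C1)c1ccc([N+](=O)[O-])cc1` and compound 4 `O=C(NN=C1CC(c2ccccc2)NC(c2ccccc2)C1)c1ccc([N+](=O)[O-])cc1[N+](=O)[O-]` share another; the difference between the two cores is not broken down here. In a functional assay, read by spectrophotometry, with a stated time of 2 h (on this read-out lower numbers stand for stronger inhibition and higher numbers for weaker inhibition), compound 1 gives 51700 nM, and compound 2 gives 60000 nM. Compound 2 differs from compound 1 by nitro in place of hydrogen on an aromatic carbon, and this change made a 1.2-fold higher number from compound 1 to compound 2 (0.06 log units; within the scatter). In this assay compound 3 gives 88100 nM, a value that lies within the scatter of those of compound 1 and compound 2, so no order among the three can be read from them. Compound 4 carries the same change on the core of compound 3: nitro in place of hydrogen on an aromatic carbon. Among the compounds with values here, the only measured instance of this change is a 1.2-fold higher number from compound 1 to compound 2 (0.06 log units; within the scatter), and on that basis a step of similar small size is expected here as well. Compound 4 is therefore expected to give about 100000 nM, most likely between 50000 nM and 200000 nM. This estimate amounts to a step of a 1.1-fold higher number from compound 3 to compound 4 (0.06 log units; within the scatter), resting on compound 3 at 88100 nM and on the earlier step of a 1.2-fold higher number from compound 1 to compound 2 (0.06 log units; within the scatter).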

Compound 4, half-maximal inhibitory concentration: 20000 nM
Beside the measured number, compound 4's estimate is 5.0-fold (0.70 log units) above it, outside the stated range (below it).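

Within the data shown here, on the core of compound 3, nitro in place of hydrogen on an aromatic carbon gives a 4.4-fold lower number from compound 3 to compound 4 (0.64 log units; beyond the scatter), which in this assay means stronger inhibition, whereas the same change on the core of compound 1 gives no step that can be told from the scatter. Among these compounds, the effect of this change therefore did not carry over from one core to the other: the same change on two cores in this assay, a 1.2-fold higher number (0.06 log units; within the scatter) from compound 1 to compound 2 and a 4.4-fold lower number (0.64 log units; beyond the scatter) from compound 3 to compound 4, 5.1-fold (0.71 log units) apart, beyond the scatter of two such steps This shows that, in this series, a step measured on one core is a poor guide to the same step on another, but it rests on only two pairs of compounds and does not show why the two cores respond differently.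

The compounds shown leave open whether other groups at the same place, such as an amine or a chlorine atom, would also act differently on the two cores. They also leave open which of the differences between the two cores matters, as the cores differ in more than one place.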